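Removing the methoxy group from a hydroxamic acid compound

The source may report more compounds than this note shows. Statements on the series, on what has been measured and on what is new or still open speak of the compounds shown alone.

Measured compounds:
Compound 1, `COc1ccc(C(=O)c2cc(/C=C/C(=O)NO)n(C)c2)cc1`: 75.2% in an assay on isolated protein for inhibition of histone deacetylase HD2 (Zea mays), tested at 30 uM; on this read-out higher numbers stand for more inhibition at the one concentration tested (going by the name of the read-out) and lower numbers for less inhibition
Compound 2, `Cn1cc(C(=O)c2ccccc2)cc1CCC(=O)NO`: 45% in this assay
Compound 3, `Cn1cc(C(=O)c2ccc(F)cc2)cc1/C=C/C(=O)NO`: 84% in this assay

Compound 1 stands second highest of the three numbers in this assay. Its nearest neighbour is compound 3, where the step of a number 8.8 percentage points higher from compound 1 to compound 3 (within the scatter) lies within the scatter. Within the data shown here, its furthest neighbour is compound 2, whose number lies well below it, beyond the scatter; compound 2 differs from compound 1 in more than one place, so no single step is drawn between them.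

Compound 4, `Cn1cc(C(=O)c2ccccc2)cc1/C=C/C(=O)NO`, differs from compound 1 as follows: hydrogen in place of methoxy on an aromatic carbon. Among the measured compounds shown here, the only measured step that bears on a change at this aromatic carbon is the one from compound 1 to compound 3, and it stayed within the scatter. On that basis, an exchange of the methoxy group for hydrogen is expected to give no step beyond the scatter in this assay, in either direction. The estimated step is a number 0.8 percentage points higher from compound 1 to compound 4 (within the scatter). Compound 4 is therefore expected to give about 76%, with a range from 60% to 90%.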

Compound 4, a percentage reported as inhibition, at one concentration (the size of the read-out at that concentration, not a potency): 86%
Estimate against measurement, compound 4: 10 percentage points below, and the stated range covers the measured number.
By their numbers in this assay, from the lowest: compound 2; then compounds 1, 3 and 4 (each within the scatter of the next, the first and the last beyond it).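

In this assay, among these compounds, the exchange of methoxy for hydrogen gives a number 10.8 percentage points higher from compound 1 to compound 4 (beyond the scatter), the first step at this aromatic carbon to pass the scatter, though only modestly. Hydrogen and fluoro at this place cannot be told apart, with a number 2 percentage points higher from compound 3 to compound 4 (within the scatter), while the much larger step belongs to the other site of change: 2-(hydroxycarbamoyl)ethenyl in place of 2-(hydroxycarbamoyl)ethyl gives a number 41 percentage points higher from compound 2 to compound 4 (beyond the scatter) in the unsubstituted compounds. Nothing at hand explains any of these steps.

From the compounds shown here alone, it remains open whether an amine or a chlorine atom at this aromatic carbon would read like hydrogen, fluoro or methoxy. Also open, going by these compounds, is whether the gap between the 2-(hydroxycarbamoyl)ethenyl and 2-(hydroxycarbamoyl)ethyl groups holds with methoxy or fluoro on the ring, and how a longer chain would read.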